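Free amino analogue of the fused pyrimidinone series

The compounds below may be only part of what the source reports. "The series", "measured", "known", "first", "only" and "open" are said of these compounds alone.

Measured so far in a functional assay on the whole organism (strain albino) for inhibition, with Rattus norvegicus as the target, read by paw edema, with stated times of 1 h and 3 h, at a dose of 20 mmol/kg by the intraperitoneal route; on this read-out lower numbers stand for a weaker effect and higher numbers for a stronger effect at the one dose given:
compound 1 `COc1ccc(N/C=N/C2=C(C#N)C3C(N4CCCC4)CCCCN3C(=O)N2c2ccccc2)cc1` gives 50.2%
compound 2 `N#CC1=C(/N=C/c2ccccc2)N(c2ccccc2)C(=O)N2CCCCC(N3CCCC3)C12` gives 84%

Compound 2 stands highest of the two numbers; its nearest neighbour is compound 1, and the step of a number 33.8 percentage points higher from compound 1 to compound 2 (beyond the scatter) lies beyond the scatter. Compound 3 `N#CC1=C(N)N(c2ccccc2)C(=O)N2CCCCC(N3CCCC3)C12` is not yet measured. The change from compound 2 to compound 3 is one nitrogen atom in place of a group of 8 heavy atoms (7 carbon, 1 nitrogen; one six-membered aromatic ring of carbon only), on a double-bonded ring carbon. Among the measured compounds shown here, no measured step touches the whole group that leaves; the one step in this assay concerns a change on the same carbon and was large, so a step beyond the scatter in either direction is plausible. Compound 3 is expected to give 60% (range 35% to 85%), meaning an estimated step of a number 24 percentage points lower from compound 2 to compound 3 (beyond the scatter).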

Compound 3, a percentage reported as inhibition, in the whole organism at one dose (the size of the read-out at that dose, not a potency): 90.1%
Compound 3: middle estimate off by 30.1 percentage points, on the low side, outside the stated range (above it).
By their numbers in this assay, from the lowest: compound 1; then compounds 2 and 3 (each within the scatter of the next).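

In this assay, one nitrogen atom in place of the whole group of 8 heavy atoms gives a number 6.1 percentage points higher from compound 2 to compound 3 (within the scatter), so the six-membered aromatic ring of that group is not required for the effect at this dose. Against compound 1, the same amino group gives a number 39.9 percentage points higher from compound 1 to compound 3 (beyond the scatter), which leaves the group on compound 1 as the only one of the three set apart beyond the scatter. Nothing available explains this outcome.

Going by these compounds, whether a methylamino or hydroxyl group on this carbon would match the amino group remains open. Also open, on these data alone, is whether compound 2 and compound 3 would stay level at other doses.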